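The source may report more compounds than this note shows. Statements on the series, on what has been measured and on what is new or still open speak of the compounds shown alone.

Measured in a physicochemical assay for solubility, read by spectrophotometry, with a stated time of 24 h, at pH 7.4; a higher number here means a more soluble compound, a lower number a less soluble compound:
- Compound 1 (`COC(=O)c1cccc(/C=N/NC(=O)c2ccc(N(C)C)cc2)c1`) gives 3700 nM as a number
- Compound 2 (`CN(/N=C/c1cccc(C(=O)O)c1)C(=O)c1ccc(N(C)C)cc1`) gives > 67000 nM as a limit
- Compound 3 (`CN(C)c1ccc(C(=O)N/N=C/c2ccc(C(=O)O)cc2)cc1`) gives > 77000 nM as a limit

Compound 3 thus stands at a limit (> 77000 nM) and has no number. Compound 4 (`CN(C)c1ccc(C(=O)N/N=C/c2ccc(C(=O)NO)cc2)cc1`) has not yet been measured and differs from compound 3 in one place (hydroxyamino in place of hydroxy on a carbonyl carbon): hydroxyamino in place of hydroxy on a carbonyl carbon, or carboxy to hydroxycarbamoyl. Among the measured compounds shown here, no measured pair shows this change. For the measured compounds named here, the expectation therefore leans on compound 1 (3700 nM), the only number available. A fall beyond the scatter is expected in this assay for this change (an at least 7.7-fold lower number from compound 3 to compound 4 (0.88 log units; beyond the scatter)). Compound 4 is estimated at 10000 nM with an expected range from 3000 nM to 40000 nM in this measurement.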

Compound 4, solubility: 15000 nM
Beside the measured number, compound 4's estimate is 1.5-fold (0.18 log units) below it; measured number inside the range.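

In this assay, hydroxyamino in place of hydroxy on a carbonyl carbon gives an at least 5.1-fold lower number from compound 3 to compound 4 (0.71 log units; beyond the scatter). This is the only step shown between compounds that differ in one place, so this position can now be read directly, and the change moves the read-out beyond the scatter. Its full size stays open because compound 3 stands at a limit and not at a number: the limit of > 77000 nM in this assay, at which 1 of the 4 values shown sits.

The compounds shown leave open how an amino or a methoxyamino group on this carbonyl carbon would read. They also leave open whether this change gives a step of like size on another core.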